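The source may report more compounds than this note shows. Statements on the series, on what has been measured and on what is new or still open speak of the compounds shown alone.

Three compounds have been measured in a functional assay on RAW264.7 cells (Mus musculus) for inhibition, read by Griess assay, with stated times of 1 h and 24 h; on this read-out higher numbers stand for weaker inhibition and lower numbers for stronger inhibition

Compound 1 `CCCOc1ccc(C(O)C2OC(=O)c3c(OC)cc(OC)cc32)cc1` gives 9260 nM
Compound 2 `CCCCOc1ccc(C(O)C2OC(=O)c3c(OC)cc(OC)cc32)cc1` gives 1800 nM
Compound 3 `COc1cc(OC)c2c(c1)C(C(O)c1ccc(OCCOc3ccccc3)cc1)OC2=O` gives > 10000 nM, which is a limit and not a number

Compound 3 therefore has no exact value and sits at the limit of > 10000 nM in this assay, at which 1 of the 3 values shown sits. The next compound, compound 4 `C=CCCOc1ccc(C(O)C2OC(=O)c3c(OC)cc(OC)cc32)cc1`, differs from it by one change: vinyl in place of phenoxy on a saturated chain carbon, two bonds along the chain from an oxygen on an aromatic ring. In short, 2-phenoxyethoxy gives way to (but-3-en-1-yl)oxy.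

The nearest guide is an at least 5.5-fold higher number from compound 2 to compound 3 (0.74 log units; beyond the scatter), which brought phenoxy in at this same place. The change to compound 4 takes it out again, so a move towards a lower number is expected in this assay. The step of an at least 1.0-fold higher number from compound 1 to compound 3 (0.03 log units; that floor lies within the scatter) adds little, since its floor lies within the scatter. The step of a 5.1-fold lower number from compound 1 to compound 2 (0.71 log units; beyond the scatter) shows that a small change in this chain can carry the number beyond the scatter, which leaves the exact landing point open. A step of at least modest size is expected, and the limit on compound 3 keeps its true size unknown. The estimated change is an at least 3.5-fold lower number from compound 3 to compound 4 (0.55 log units; beyond the scatter). For compound 4 the expected value is 2800 nM, with an estimated range of 1100 nM to 7500 nM.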

Compound 4, half-maximal inhibitory concentration: 1330 nM
Beside the measured number, compound 4's estimate is 2.1-fold (0.32 log units) above it; the range from low to high includes it.
By their numbers in this assay, from the lowest: compounds 4 and 2 (each within the scatter of the next); then compound 1. At a limit, above all of these: compound 3.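

Taking phenoxy out of the chain and setting vinyl in its place, on the saturated chain carbon two bonds along the chain from the oxygen on the aromatic ring, gives an at least 7.5-fold lower number from compound 3 to compound 4 (0.87 log units; beyond the scatter) in this assay, so this place in the chain can still carry a number well clear of the limit once phenoxy has gone. Among the compounds shown here, what the earlier compounds did not show is that vinyl and ethyl at this place cannot be told apart, with a 1.4-fold lower number from compound 2 to compound 4 (0.13 log units; within the scatter), while vinyl stands clearly apart from methyl, with a 7.0-fold lower number from compound 1 to compound 4 (0.84 log units; beyond the scatter). The step away from phenoxy is only a floor, as compound 3 has a limit and not a number: the limit of > 10000 nM in this assay, at which 1 of the 4 values shown sits.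

On these data alone, the true size of that step remains open, and so does the question of whether a longer chain, such as a hexyl or octyl ether, would lower the number further in this assay. Also open, as far as these compounds go, is how an amine or a carboxylic acid at the end of the chain would read in place of vinyl.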